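Swapping the Amide Substituent: Compound 3 to Compound 4

The source may hold more compounds than are shown below. What is called first, only, known or untested is meant among the compounds shown, and "the series" means these compounds.

This series shares a core carrying a pentafluorophenylsulfonyl azetidine amide, and its members are compared in an ADME assay on MCF-10A cells (Homo sapiens) for cytotoxicity, with a stated time of 72 h; a lower number here means that less compound is needed, a higher number that more compound is needed for the effect. Compound 1 `COC(=O)c1ccc(N(Cc2cnc(C3CCCCC3)cn2)C(=O)[C@H]2CCN2S(=O)(=O)c2c(F)c(F)c(F)c(F)c2F)c(F)c1` gives 4000 nM. Compound 2 `O=C(NO)c1ccc(N(Cc2ccc(C3CCCCC3)cc2)C(=O)[C@H]2CCN2S(=O)(=O)c2c(F)c(F)c(F)c(F)c2F)cc1O` gives 7500 nM, and the two values sit close enough that no order between them is claimed. Compound 3 `CONC(=O)c1ccc(N(Cc2ccc(C3CCCCC3)cn2)C(=O)[C@H]2CCN2S(=O)(=O)c2c(F)c(F)c(F)c(F)c2F)c(F)c1` was run in the same setting, but compound 3 gives only "not determined" (no result reported), so compound 3 stands without a number of its own and can only be placed next to compound 1 and compound 2.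

Compound 4 `O=C([C@H]1CCN1S(=O)(=O)c1c(F)c(F)c(F)c(F)c1F)N(Cc1ccc(C2CCCCC2)cn1)c1ccc2c(=O)[nH]cnc2c1` differs from compound 3 at the amide-type nitrogen: a group of 11 heavy atoms (8 carbon, 2 nitrogen, 1 oxygen; one six-membered aromatic ring of carbon only, one six-membered aromatic ring with 2 hetero atoms) in place of a group of 12 heavy atoms (8 carbon, 1 nitrogen, 2 oxygen, 1 fluorine; one six-membered aromatic ring of carbon only), on an amide-type nitrogen. Among the compounds with values here, no measured step of this kind exists here, so the size of the change in this assay cannot be read off from earlier pairs. Since compound 1 and compound 2 stay in a narrow band despite differing groups on that nitrogen, compound 4 is expected to land near that band, at an estimated 5000 nM, within a range of 1500 nM to 16000 nM.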

Compound 4, half-maximal effective concentration: 4000 nM
Estimate against measurement, compound 4: 1.3-fold (0.10 log units) above, and the stated range covers the measured number.
By their numbers in this assay, from the lowest: compounds 1, 4 and 2 (each within the scatter of the next).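

Within the data shown here, compound 3 has no number of its own, so the swap from compound 3 to compound 4 yields no step that can be read. What replacing the 2-fluoro-4-(methoxycarbamoyl)phenyl group does in this assay stays open, and no supporting data explain the value of compound 4.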